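Hydroxy to methoxy: compound 1 toward compound 4

The compounds below may be only part of what the source reports. "The series", "measured", "known", "first", "only" and "open" are said of these compounds alone.

Measured set in a functional assay on J774 cells (Mus musculus) for cytotoxicity, read by resazurin assay, with a stated time of 72 h; on this read-out higher numbers stand for weaker inhibition and lower numbers for stronger inhibition:
compound 1 `O=S(=O)(Nc1cc(CO)ccc1O)c1ccc(-c2ccc(Br)cc2)cc1` — 1000 nM
compound 2 `O=S(=O)(Nc1cc(CO)ccc1O)c1ccc(-c2ccc(F)cc2F)cc1` — 200 nM
compound 3 `O=S(=O)(Nc1cccc(CO)c1)c1ccc(-c2ccc(F)cc2)cc1` — 3500 nM

Compound 1 stands second highest of the three numbers. Its nearest neighbour is compound 3, whose number is higher; compound 2 lies furthest from it, with a lower number. Going by the values given here, the one step that can be read directly, a 5.0-fold lower number from compound 1 to compound 2 (0.70 log units; beyond the scatter), replaces the 4-bromophenyl group and leaves the rest of the molecule untouched. Compound 3 differs from compound 1 in two places at once, at the hydroxy and at the halogen, so its higher number cannot be assigned to either change alone.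

Compound 4 `COc1ccc(CO)cc1NS(=O)(=O)c1ccc(-c2ccc(Br)cc2)cc1` carries the change (methyl in place of hydrogen on an oxygen on an aromatic ring), methyl in place of hydrogen on an oxygen on an aromatic ring; one bond further out this reads hydroxy to methoxy. Among the compounds with values here, no measured step touches this oxygen, and the step from compound 1 to compound 2 concerns a different part of the molecule, so it gives no direction here. Compound 3 shows only that loss of the hydroxy, together with a halogen swap, went with a higher number. The estimate for compound 4 is therefore a modest step toward a higher number in this assay, a 2.0-fold higher number from compound 1 to compound 4 (0.30 log units; within the scatter), with a result within the scatter not excluded. Compound 4 is expected at 2000 nM, within a range of 700 nM to 6000 nM.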

Compound 4, half-maximal inhibitory concentration: 2500 nM
Beside the measured number, compound 4's estimate is 1.3-fold (0.10 log units) below it; the range from low to high includes it.
By their numbers in this assay, from the lowest: compound 2; then compound 1; then compounds 4 and 3 (each within the scatter of the next).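

In this assay, going by these compounds alone, a 2.5-fold higher number from compound 1 to compound 4 (0.40 log units; beyond the scatter) gives the first reading that isolates this oxygen: hydroxy to methoxy, with the rest of the molecule unchanged. Compound 3 could not supply this reading, since it differs from compound 1 in two places at once, whereas here a single methyl in place of hydrogen moves the number modestly toward weaker inhibition, and the size of that move lies beyond the usual scatter. No measurement at hand explains the step, so the result stands as an observation about this one pair, with the 4-bromophenyl group in place.

The compounds shown leave open whether the same change would give a step of similar direction and size on the 2,4-difluorophenyl background of compound 2. They also leave open how the number would respond to a longer chain on this oxygen, such as ethyl or propyl, or to an amine or a fluorine in place of the hydroxy, so a single methyl step does not yet describe the position as a whole.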